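Chain length at the amide nitrogen: from phenyl to phenethyl

The compounds below may be only part of what the source reports. "The series", "measured", "known", "first", "only" and "open" are said of these compounds alone.

Compound 1 `CCCn1c(=O)[nH]c2nc(-c3ccc(OCC(=O)NCCCCc4ccccc4)cc3)[nH]c2c1=O` and compound 2 `CCCn1c(=O)[nH]c2nc(-c3ccc(OCC(=O)NCc4ccccc4)cc3)[nH]c2c1=O` share one core and differ only at the saturated chain carbon bound to the amide-type nitrogen. In an assay on cell membranes for displacement of a labelled ligand from adenosine receptor A1 (Rattus norvegicus), read by scintillation counting, with a stated time of 90 min (on this read-out lower numbers stand for stronger inhibition and higher numbers for weaker inhibition), compound 1 gives 29.6 nM, and compound 2 gives 27.2 nM; the step of a 1.1-fold lower number from compound 1 to compound 2 (0.04 log units; within the scatter) is within the scatter. Compound 3 `CCCn1c(=O)[nH]c2nc(-c3ccc(OCC(=O)NCCCc4ccccc4)cc3)[nH]c2c1=O` carries phenethyl in place of phenyl on a saturated chain carbon bound to an amide-type nitrogen. Within the data shown here, only the step from compound 1 to compound 2 bears on this change, and it was within the scatter, so no step beyond the scatter is expected in this assay. Compound 3 is therefore estimated at 28 nM, between 14 nM and 56 nM, an expected step of a 1.0-fold higher number from compound 2 to compound 3 (0.01 log units; within the scatter).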

Compound 3, inhibition constant: 35.3 nM
Estimate against measurement, compound 3: 1.3-fold (0.10 log units) below, and the stated range covers the measured number.
By their numbers in this assay, from the lowest: compounds 2, 1 and 3 (each within the scatter of the next).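

Phenethyl in place of phenyl at this position, on a saturated chain carbon bound to an amide-type nitrogen, adds a further chain length, and the number in this assay does not move beyond the scatter (a 1.3-fold higher number from compound 2 to compound 3 (0.11 log units; within the scatter)). The step to compound 3 from the other side is also within the scatter (a 1.2-fold higher number from compound 1 to compound 3 (0.08 log units; within the scatter)), so all three chain lengths shown are indistinguishable at this position. On these data alone, whether a longer chain, or an amine or a carboxylic acid at the chain end, would give a step beyond the scatter stays open. Nothing given here explains why the chain length makes no visible difference.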